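A few compounds are considered here, and "the series" means these few. Any claim that something is new, unique, unknown or untested is made for them only; others in the source may bear on it.

Measured compounds and their values in a functional assay on MGC-803 cells (Homo sapiens) for antiproliferative activity, read by MTT assay; on this read-out higher numbers stand for weaker inhibition and lower numbers for stronger inhibition:
- compound 1, `Cc1ccc(NC(=O)Nc2cccc(CNc3ncnc4ccccc34)c2)cc1`: 31200 nM
- compound 2, `O=C(Nc1ccc([N+](=O)[O-])cc1)Nc1cccc(CNc2ncnc3ccccc23)c1`: 9420 nM
- compound 3, `COc1cc2ncnc(NCc3cccc(NC(=O)Nc4ccccc4C)c3)c2cc1OC`: > 50000 nM

Compound 3 stands apart from the other two in that it gives no number in this assay. For compound 3 the result is a limit, (the limit of > 50000 nM in this assay, at which 1 of the 3 values shown sits), so its inhibition is weaker than anything this assay can put a figure on. Compound 4, `COc1cc2ncnc(NCc3cccc(NC(=O)Nc4ccc(C)cc4)c3)c2cc1OC`, keeps the whole of compound 3 but moves the methyl on the outer ring: 4-methylphenyl in place of 2-methylphenyl on an amide-type nitrogen.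

Among the measured compounds shown here, no measured step matches this change. For the measured compounds named here, the only step that has been measured, a 3.3-fold lower number from compound 1 to compound 2 (0.52 log units; beyond the scatter), swaps one group for another at the same place and says nothing about moving a methyl from one position to another. What can be drawn on is compound 1, which carries the 4-methylphenyl on the urea but a different shared core, and gives 31200 nM in this assay, a number inside the measurable range. Compound 4 is therefore expected to land near the limit of compound 3 or somewhat inside the range, giving an estimate of 40000 nM with a span from 12000 nM to 120000 nM, and the step from compound 3 is expected to be an at least 1.2-fold lower number from compound 3 to compound 4 (0.09 log units; that floor lies within the scatter), though with only a limit for compound 3 its size cannot be fixed.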

Compound 4, half-maximal inhibitory concentration: 34200 nM
Estimate against measurement, compound 4: 1.2-fold (0.07 log units) above; the measured number falls inside the stated range.
By their numbers in this assay, from the lowest: compound 2; then compounds 1 and 4 (each within the scatter of the next). At a limit, above all of these: compound 3.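

Moving the methyl on the outer ring, with the rest of the molecule unchanged, yields a figure where there was none: in this assay, compound 4 gives 34200 nM. Compound 3 remains a limit and not a number: the limit of > 50000 nM in this assay, at which 1 of the 4 values shown sits.

As far as these compounds go, replacing 2-methylphenyl with 4-methylphenyl on this amide-type nitrogen therefore comes to an at least 1.4-fold lower number from compound 3 to compound 4 (0.16 log units; that floor lies within the scatter), which shows that the place of the methyl on the outer ring can decide whether this core gives a readable value, but only a floor can be read, so the true size of the step remains unknown.

Still open, from the compounds shown here alone, is whether nitro in place of the methyl on the outer ring would carry over to the shared core of compound 3 and compound 4, given that the same swap on the other core gave a 3.3-fold lower number from compound 1 to compound 2 (0.52 log units; beyond the scatter). Also open, going by these compounds, is how this core would respond to other groups on the outer ring, such as a chlorine, a methoxy group, an amine or a carboxylic acid.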